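Swapping an aryl for a ketone-bearing ring on the triazole

The source may report more compounds than this note shows. Statements on the series, on what has been measured and on what is new or still open speak of the compounds shown alone.

Of the compounds shown here, three sharing one core have been measured in a functional assay on MDA-MB-231 cells (Homo sapiens) for cytotoxicity, read by MTT assay, with a stated time of 48 h; on this read-out higher numbers stand for weaker inhibition and lower numbers for stronger inhibition. Compound 1 `O=C1C[C@H](OCc2cn(C(=O)c3ccccc3)nn2)[C@H]2CO[C@@H]1O2` gives 25900 nM. Compound 2 `O=C1C[C@H](OCc2cn(-c3ccc(F)cc3)nn2)[C@H]2CO[C@@H]1O2` gives 23700 nM, and compound 3 `O=C1C[C@H](OCc2cn(-c3ccccc3Cl)nn2)[C@H]2CO[C@@H]1O2` gives 26400 nM. Among these, compound 3 holds the largest number, yet this means little: the steps that lead to it, a 1.0-fold higher number from compound 1 to compound 3 (0.01 log units; within the scatter) and a 1.1-fold higher number from compound 2 to compound 3 (0.05 log units; within the scatter), are both within the scatter, as is a 1.1-fold lower number from compound 1 to compound 2 (0.04 log units; within the scatter).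

Compound 4 `O=C1CCCCC1n1cc(CO[C@H]2CC(=O)[C@@H]3OC[C@H]2O3)nn1` is not yet measured. It differs from compound 3 by 2-oxocyclohexyl in place of 2-chlorophenyl on an aromatic nitrogen. The two measured steps that bear on this change are those that also exchange the group on that aromatic nitrogen, a 1.0-fold higher number from compound 1 to compound 3 (0.01 log units; within the scatter) and a 1.1-fold higher number from compound 2 to compound 3 (0.05 log units; within the scatter), and neither reached beyond the scatter. On that basis no step beyond the scatter is expected in this assay, so the move a 1.0-fold lower number from compound 3 to compound 4 (0.01 log units; within the scatter) is an estimate of essentially no change. Compound 4 is therefore expected to give about 26000 nM, with a plausible range from 12000 nM to 55000 nM.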

Compound 4, half-maximal inhibitory concentration: 36000 nM
Beside the measured number, compound 4's estimate is 1.4-fold (0.14 log units) below it; low and high end bracket the measured number.
By their numbers in this assay, from the lowest: compounds 2, 1, 3 and 4 (each within the scatter of the next).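

Among the compounds shown here, at this aromatic nitrogen the earlier compounds carry only aryl or benzoyl groups, and compound 4 extends the comparison to a non-aromatic ring, 2-oxocyclohexyl, which also brings one hydrogen-bond acceptor. In this assay, a 1.4-fold higher number from compound 3 to compound 4 (0.13 log units; within the scatter) and a 1.5-fold higher number from compound 2 to compound 4 (0.18 log units; within the scatter) and a 1.4-fold higher number from compound 1 to compound 4 (0.14 log units; within the scatter) all lie within the scatter, so replacing either aryl group or the benzoyl group with this ring produces no resolved change. No supporting measurement is available to explain these steps.

From the compounds shown here alone, whether an amine, a carboxylic acid or a longer chain on this aromatic nitrogen would move the number beyond the scatter remains open. With all four compounds lying within the scatter of their neighbours, the series also leaves open whether the group at this position can influence this read-out at all.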